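Swapping the Aryl Group: An Estimate for Compound 3

This account rests on a few compounds, and the source may have more. Where it says the series, first, only, none or still open, it means among the compounds named here.

Measured compounds:
- compound 1, `CNC(=O)c1cc(Oc2ccc(C3=NNC(c4cc(OC)c(OC)c(OC)c4)C3)cc2)ccn1`: 24300 nM
- compound 2, `CNC(=O)c1cc(Oc2ccc(C3=NNC(c4cccc([N+](=O)[O-])c4)C3)cc2)ccn1`: 26500 nM

Of the compounds shown here, two sharing one core have been tested in a functional assay on HepG2 cells (Homo sapiens) for cytotoxicity, read by MTT assay, with a stated time of 72 h; on this read-out lower numbers stand for stronger inhibition and higher numbers for weaker inhibition. Compound 1 gives 24300 nM in this assay, and compound 2 gives 26500 nM. Among the measured compounds shown here, compound 2 holds the higher of the two numbers, yet its only neighbour, compound 1, sits within the usual scatter of such a measurement, so the pair cannot be ordered: both simply show weak inhibition in this assay.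

The next compound, compound 3, `CNC(=O)c1cc(Oc2ccc(C3=NNC(c4ccc(Br)cc4)C3)cc2)ccn1`, is built from compound 2 by a single exchange on the saturated ring carbon: 4-bromophenyl in place of 3-nitrophenyl on a saturated ring carbon. For the measured compounds named here, no step between two measured compounds is available to calibrate this exchange, and the one comparison on hand, between a trimethoxyphenyl and a nitrophenyl, moved the number hardly at all. Compound 3 is therefore expected to land close to compound 2, with a step of a 1.2-fold lower number from compound 2 to compound 3 (0.08 log units; within the scatter) that does not clearly exceed the scatter. The estimate for compound 3 in this assay is 22000 nM, expected to fall between 8000 nM and 60000 nM.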

Compound 3, half-maximal inhibitory concentration: 57600 nM
For compound 3 the middle estimate is 2.6-fold (0.42 log units) below the measured one; the measured number falls inside the stated range.
By their numbers in this assay, from the lowest: compounds 1 and 2 (each within the scatter of the next); then compound 3.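

In this assay, replacing 3-nitrophenyl with 4-bromophenyl on the saturated ring carbon gives a 2.2-fold higher number from compound 2 to compound 3 (0.34 log units; beyond the scatter), the one step shown here that clears the scatter, so the group at this position can shift the read-out even though the earlier pair of compounds could not be ordered. The shift is modest and runs toward weaker inhibition, which shows that this exchange moves the shared core away from stronger inhibition rather than leaving it unchanged. No supporting measurement bears on why this exchange has that effect.

The exchange changes both the substituent and its place on the phenyl ring, so the compounds shown cannot separate the effect of bromine from that of its location, a question that 3-bromophenyl and 4-nitrophenyl would address directly. From the compounds shown here alone, it also remains open whether any other group on this carbon, such as an aminophenyl or a carboxyphenyl, would move the number in the opposite direction, since every step available so far offers no route to stronger inhibition.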